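This account rests on a few compounds, and the source may have more. Where it says the series, first, only, none or still open, it means among the compounds named here.

Measured compounds:
Compound 1, `COc1ccc(-c2cc(-c3ccccc3-c3ccccc3)n[nH]2)cc1`, in a functional assay on NCI-H460 cells (Homo sapiens) for inhibition, read by MTT assay, with a stated time of 48 h (on this read-out lower numbers stand for stronger inhibition of growth and higher numbers for weaker inhibition of growth), gives 730 nM.
Compound 2, `Oc1ccc(-c2cc(-c3ccccc3-c3ccccc3)n[nH]2)cc1`, in this assay gives 6900 nM.

Compound 2 stands highest of these two numbers in this assay; its nearest neighbour is compound 1, and the step of a 9.5-fold higher number from compound 1 to compound 2 (0.98 log units; beyond the scatter) lies beyond the scatter. The unmeasured compound 3, `O=[N+]([O-])c1ccc(-c2cc(-c3ccccc3-c3ccccc3)n[nH]2)cc1`, differs from compound 2 by nitro in place of hydroxy on an aromatic carbon. For the measured compounds named here, only one measured step exists, and it bears on this change merely in part: the exchange from compound 1 to compound 2 put hydrogen in place of methyl on the oxygen and gave a 9.5-fold higher number from compound 1 to compound 2 (0.98 log units; beyond the scatter). Going by the values given here, no measured pair contains a nitro group, so the direction for compound 3 cannot be read from a like-for-like step. Among the compounds with values here, the hydroxy group of compound 2 leaves in compound 3, and since the only measured pair without hydroxy, compound 1, sits at 730 nM, compound 3 is expected to move back toward that lower number, by a step of a 3.5-fold lower number from compound 2 to compound 3 (0.54 log units; beyond the scatter), though with wide uncertainty. The estimate for compound 3 in this assay is 2000 nM, with a range from 500 nM to 10000 nM.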

Compound 3, concentration for 50% growth inhibition: 2700 nM
Compound 3: middle estimate off by 1.4-fold (0.13 log units), on the low side; measured number inside the range.
By their numbers in this assay, from the lowest: compound 1; then compound 3; then compound 2.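

With a nitro group on the aromatic carbon para to a large group, the compounds in this assay now include a group at this place that is not joined through a single oxygen, and the outcome differs depending on which group it replaces. Nitro in place of hydroxy gives (a 2.6-fold lower number from compound 2 to compound 3 (0.41 log units; beyond the scatter)) while nitro in place of methoxy gives (a 3.7-fold higher number from compound 1 to compound 3 (0.57 log units; beyond the scatter)), so the new group falls between the two earlier ones and neither recovers the number of compound 1 nor stays at that of compound 2. The position therefore responds to each of these exchanges beyond the scatter, but nothing at hand accounts for this order of methoxy, nitro and hydroxy.

On these data alone, three groups at one position cannot show what governs the order, and it remains open where an amine, a carboxylic acid, a fluorine atom or a longer alkoxy chain such as ethoxy would fall at this place. As far as these compounds go, it is also open whether the same order would hold if the rest of the shared core were changed, or in any cells other than those of this assay.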